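Cyclopentylamino in Place of 2-Methoxyethoxy

The compounds below may be only part of what the source reports. "The series", "measured", "known", "first", "only" and "open" are said of these compounds alone.

Compound 1 `CNc1nc(N)nc2c1ncn2/C=C1/CC1(CO)CO` and compound 2 `COCCOc1nc(N)nc2c1ncn2/C=C1/CC1(CO)CO` share one core and differ at a single aromatic carbon, where compound 2 carries 2-methoxyethoxy in place of methylamino. In an ADME assay on CCRF-HSB-2 cells (Homo sapiens) for cytotoxicity, with a stated time of 7 days (a lower number here means that less compound is tolerated, a higher number that more compound is tolerated), compound 1 gives only the assay limit > 20000 nM and no number. In this assay compound 2 likewise gives only the limit > 20000 nM. The step that the two limits leave unreadable from compound 1 to compound 2 therefore cannot be read, since (the limit of > 20000 nM in this assay, at which 2 of the 2 values shown sit). Compound 3 `Nc1nc(NC2CCCC2)c2ncn(/C=C3/CC3(CO)CO)c2n1` differs from compound 2 by cyclopentylamino in place of 2-methoxyethoxy on an aromatic carbon. Among the measured compounds shown here, no measured step bears on this change in a readable way; both measured values are limits, so neither a size nor a direction can be drawn from them. For compound 3 in this assay the expectation is therefore a step of a number no higher from compound 2 to compound 3 (the limit leaves the size open) that stays at the limit rather than one beyond the scatter. Compound 3 is expected to give about 20000 nM, within 8000 nM to 40000 nM.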

Compound 3, half-maximal cytotoxic concentration: > 20000 nM
Compound 3: no number, only a limit (the forecaster's own chance of this, stated with the estimate: 75%); the middle value lies on the limit itself.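

Compound 3 also gives only a limit in this assay, so no step among compound 1, compound 2 and compound 3 can be read: the limit of > 20000 nM in this assay, at which 3 of the 3 values shown sit.

The compounds shown leave open whether methylamino, 2-methoxyethoxy and cyclopentylamino differ at all in this assay.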